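This account rests on a few compounds, and the source may have more. Where it says the series, first, only, none or still open, it means among the compounds named here.

Compound 1 `O=c1cc(/C=N\c2ccccc2O)c2ccc(OCc3ccccc3)cc2o1` opens the account; in a functional assay, read by spectrophotometry, with a stated time of 5 min (on this read-out lower numbers stand for stronger inhibition and higher numbers for weaker inhibition), compound 1 gives 469000 nM. Among the two numbers recorded, compound 1 stands highest, and its nearest neighbour is compound 2 `O=c1cc(/C=N\c2ccccc2O)c2c(OCc3ccccc3)cc(OCc3ccccc3)cc2o1`, which in this assay gives 33100 nM. Among the measured compounds shown here, the single step recorded, a 14-fold lower number from compound 1 to compound 2 (1.15 log units; beyond the scatter), concerns a benzyloxy in place of hydrogen on an aromatic carbon and says nothing about the double-bonded nitrogen.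

Compound 3 `O=c1cc(/C=N\O)c2ccc(OCc3ccccc3)cc2o1` has not yet been measured. It differs from compound 1 as follows: hydroxy in place of 2-hydroxyphenyl on a double-bonded nitrogen. The hydroxy enters on a double-bonded nitrogen whose other neighbours are carbon with a double bond to nitrogen. For the measured compounds named here, no measured pair shows this change, so there is no step to draw on; the only known step bears on another part of the shared core, and the 2-hydroxyphenyl that leaves is a sizeable piece. With nothing to anchor it, the expected step of a 1.5-fold higher number from compound 1 to compound 3 (0.17 log units; within the scatter) is a modest move toward a higher number, though a step within the scatter cannot be excluded. Compound 3 is therefore estimated at 700000 nM, with a range from 150000 nM to 2500000 nM.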

Compound 3, half-maximal inhibitory concentration: > 2000000 nM
Compound 3: a limit, no number; the forecaster's own chance of this, stated with the estimate: 30%; middle value at least 2.8-fold (0.45 log units) away from the limit.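

In this assay compound 3 gives > 2000000 nM, a limit of the assay and not a number, and the only such reading among the compounds shown: the limit of > 2000000 nM in this assay, at which 1 of the 3 values shown sits.

Even so, hydroxy in place of 2-hydroxyphenyl on a double-bonded nitrogen gives an at least 4.2-fold higher number from compound 1 to compound 3 (0.62 log units; beyond the scatter), so this position, which the earlier benzyloxy step did not touch, does bear on the read-out, and the change goes toward weaker inhibition. The hydrogen-bond donor and acceptor counts are the same in the group that leaves and the group that enters, whereas the six-membered aromatic ring and most of the heavy atoms go, which narrows what differs in this change without showing which part of it matters.

The compounds shown leave open how much of the loss belongs to the ring of the 2-hydroxyphenyl and how much to the hydroxy it carries, and whether a plain phenyl or an amine on the double-bonded nitrogen would stay near compound 1. They also leave open whether benzyloxy in place of hydrogen on an aromatic carbon would still lower the number once hydroxy stands on that nitrogen.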